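Moving a fluorine on the piperazine aryl group

The compounds below may be only part of what the source reports. "The series", "measured", "known", "first", "only" and "open" are said of these compounds alone.

Compound 1 `Nc1scc(CN2CCN(c3cccnc3)CC2)c1C(=O)c1ccc(Cl)cc1`: -23%
Compound 2 `Nc1scc(CN2CCN(c3c(F)cccc3F)CC2)c1C(=O)c1ccc(Cl)cc1`: -80%

In a functional assay on CHO cells with adenosine receptor A1 (Homo sapiens) as the target, read by cAMP accumulation and immunoassay, with a stated time of 6 min, tested at 10 uM (a lower number here means a stronger effect, a higher number a weaker effect of the compound at the concentration tested), compound 2 gives -80%, the lowest of the two numbers, with compound 1 at -23%. Within the data shown here, the one measured step, a number 57 percentage points lower from compound 1 to compound 2 (beyond the scatter), changed the whole aryl group and so says little about shifting one fluorine. Compound 3 `Nc1scc(CN2CCN(c3cccc(F)c3F)CC2)c1C(=O)c1ccc(Cl)cc1` differs from compound 2 by 2,3-difluorophenyl in place of 2,6-difluorophenyl on an amine nitrogen in a ring. Among the measured compounds shown here, with no step that bears on this change, a moderate loss of effect is expected, that is a step of a number 25 percentage points higher from compound 2 to compound 3 (beyond the scatter). Compound 3 is therefore estimated at -55%, between -90% and -15%.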

Compound 3, a percentage reported as activity, at one concentration (the size of the read-out at that concentration, not a potency): -79%
Estimate against measurement, compound 3: 24 percentage points above, and the stated range covers the measured number.
By their numbers in this assay, from the lowest: compounds 2 and 3 (each within the scatter of the next); then compound 1.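

In this assay, 2,3-difluorophenyl and 2,6-difluorophenyl on the amine nitrogen in the ring cannot be told apart, with a number 1 percentage points higher from compound 2 to compound 3 (within the scatter) as the step between them. The large step away from pyridin-3-yl recurs with the second difluorophenyl group, as a number 56 percentage points lower from compound 1 to compound 3 (beyond the scatter), so it is not tied to 2,6-difluorophenyl alone. Nothing available explains why these two groups read alike. On these data alone, whether an unsubstituted phenyl, or a phenyl carrying a single fluorine or a methoxy group, would hold this read-out stays open.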